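The compounds below may be only part of what the source reports. "The series", "measured", "known", "first", "only" and "open" are said of these compounds alone.

Measured so far in a physicochemical assay for solubility, at pH 2; on this read-out lower numbers stand for lower solubility and higher numbers for higher solubility:
compound 1 `CNc1nc(OCCCN(C)C)c2sc(-c3ccc(C(F)(F)F)cc3)cc2n1` gives 174 ug/mL
compound 2 `CNc1nc(NC2CC2)c2sc(-c3ccc(C(F)(F)F)cc3)cc2n1` gives 120 ug/mL
compound 3 `CNc1nc(N2CCC(N)CC2)c2sc(-c3ccc(C(F)(F)F)cc3)cc2n1` gives > 200 ug/mL, which is a limit of this assay and not a number.

Compound 1 stands highest of the two plain numbers, with compound 2 nearest; that gap, a 1.5-fold lower number from compound 1 to compound 2 (0.16 log units; within the scatter), sits within the scatter. The value of compound 3 is only a limit (the limit of > 200 ug/mL in this assay, at which 1 of the 3 values shown sits). The new compound 4 `CNc1nc(NC2CCOCC2)c2sc(-c3ccc(C(F)(F)F)cc3)cc2n1` differs from compound 1 in one place: (oxan-4-yl)amino in place of 3-(dimethylamino)propoxy on an aromatic carbon. Two measured steps start from compound 1 and exchange the same chain: a 1.5-fold lower number from compound 1 to compound 2 (0.16 log units; within the scatter) and an at least 1.1-fold higher number from compound 1 to compound 3 (0.06 log units; that floor lies within the scatter); neither moved this assay beyond the scatter. The same is expected here, a step of a 1.3-fold lower number from compound 1 to compound 4 (0.13 log units; within the scatter), nothing beyond the scatter. Compound 4 is therefore estimated at 130 ug/mL, with a range from 55 ug/mL to 200 ug/mL.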

Compound 4, solubility: < 5 ug/mL
Compound 4: no number, only a limit (the forecaster's own chance of this, stated with the estimate: 20%); middle value at least 26-fold (1.41 log units) away from the limit.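

In this assay compound 4 gives < 5 ug/mL, which is a limit of the assay and not a number. The earlier exchanges on this aromatic carbon, next to the ring nitrogen, stayed within the scatter, but this position can carry large steps: an at least 34-fold lower number from compound 1 to compound 4 (1.54 log units; beyond the scatter) and an at least 40-fold lower number from compound 3 to compound 4 (1.60 log units; beyond the scatter). Lacking a further amine is not the whole story: swapping only cyclopropyl for oxan-4-yl gives an at least 24-fold lower number from compound 2 to compound 4 (1.38 log units; beyond the scatter).

Going by these compounds, the true size of these steps stays open. So does whether a cyclohexylamino group, or a piperidin-4-ylamino group with a ring nitrogen in place of the oxan-4-yl oxygen, would behave like cyclopropylamino.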